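Swapping a Halogenated Phenyl on Two Related Cores

The source may report more compounds than this note shows. Statements on the series, on what has been measured and on what is new or still open speak of the compounds shown alone.

Compound 1 `COc1cc(/C=C2\CN(C)C/C(=C\c3ccc(Br)cc3)C2=O)cc(OC)c1` and compound 2 `COc1cc(/C=C2\CN(C)C/C(=C\c3ccc(Cl)cc3Cl)C2=O)cc(OC)c1` share one core, while compound 3 `CN1C/C(=C\c2ccc(Br)cc2)C(=O)/C(=C/c2cccc([N+](=O)[O-])c2)C1` and compound 4 `CN1C/C(=C\c2cccc([N+](=O)[O-])c2)C(=O)/C(=C/c2ccc(Cl)cc2Cl)C1` share another; the difference between the two cores is not broken down here. In a functional assay on K562 cells (Homo sapiens) for cytotoxicity, read by MTT assay, with a stated time of 24 h (on this read-out higher numbers stand for weaker inhibition and lower numbers for stronger inhibition), compound 1 gives 7420 nM. In this assay compound 2 gives 11900 nM. The change between them is 2,4-dichlorophenyl in place of 4-bromophenyl on a double-bonded chain carbon bound to a double-bonded ring carbon, and it made a 1.6-fold higher number from compound 1 to compound 2 (0.21 log units; within the scatter). For compound 3, this assay reports only a limit, > 20000 nM, a value sitting at the limit of > 20000 nM in this assay, at which 1 of the 3 values shown sits. The same change, (2,4-dichlorophenyl in place of 4-bromophenyl on a double-bonded chain carbon bound to a double-bonded ring carbon), leads from compound 3 to compound 4. Resting on the step of a 1.6-fold higher number from compound 1 to compound 2 (0.21 log units; within the scatter), which stayed within the scatter, a change of a step that the limit leaves unreadable from compound 3 to compound 4 is expected. Compound 4 is therefore estimated at 30000 nM, most likely between 14000 nM and 70000 nM, and is expected to be reported again only as a limit.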

Compound 4, half-maximal inhibitory concentration: 12400 nM
Compound 4: middle estimate off by 2.4-fold (0.38 log units), on the high side; measured number below the stated range.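

Carried to the second core in this assay, the same change gave an at least 1.6-fold lower number from compound 3 to compound 4 (0.20 log units; that floor lies within the scatter). Compound 3 is recorded only as a limit, > 20000 nM. The pair therefore shows no more than a floor for the step on this core, and it does not show whether the change carries over unaltered from one core to the other: the same change on two cores in this assay, a 1.6-fold higher number (0.21 log units; within the scatter) from compound 1 to compound 2 and an at least 1.6-fold lower number (0.20 log units; that floor lies within the scatter) from compound 3 to compound 4; the limit leaves it open whether they differ

The compounds shown leave open how a phenyl carrying an amine or a carboxylic acid would read on a double-bonded chain carbon bound to a double-bonded ring carbon. They also leave open how the two cores compare with each other when everything else is held the same.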